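The compounds below may be only part of what the source reports. "The series", "measured", "known", "first", "only" and "open" are said of these compounds alone.

Compound 3, with structure `CCCCC#Cc1cncc(OC[C@@H]2CCCN2C)c1`, gives 1.4 nM in an assay on a protein complex for binding affinity to Neuronal acetylcholine receptor; alpha4/beta2 (Rattus norvegicus); a higher number here means a weaker inhibitor, a lower number a stronger inhibitor; among the three measured compounds it stands second highest, within the scatter of compound 1 and beyond it only against compound 2. Compound 1, `CN1CCC[C@H]1COc1cncc(C#CCCCCF)c1`, gives 0.95 nM, and compound 2, `CN1CCC[C@H]1COc1cncc(C#CC(C)(C)O)c1`, gives 2.9 nM. Compound 4, `CN1CCC[C@H]1COc1cncc(C#CCO)c1`, differs from compound 3 by hydroxy in place of propyl on a saturated chain carbon bound to a triple-bonded carbon. Going by the values given here, two measured steps bear on this: a 3.1-fold higher number from compound 1 to compound 2 (0.48 log units; beyond the scatter) and a 2.1-fold lower number from compound 2 to compound 3 (0.32 log units; beyond the scatter), each showing a modest weakening when a hydroxyl-bearing short group replaces an unsubstituted chain on the triple-bonded carbon. Compound 4 carries a hydroxymethyl in place of the butyl, so a similar modest weakening is expected, a 2.9-fold higher number from compound 3 to compound 4 (0.46 log units; beyond the scatter). Compound 4 is therefore estimated at 4 nM, expected to lie between 1.5 nM and 11 nM.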

Compound 4, inhibition constant: 0.93 nM
Compound 4: the middle estimate sits 4.3-fold (0.63 log units) above what was measured, and the stated range ends above it.
By their numbers in this assay, from the lowest: compounds 4, 1 and 3 (each within the scatter of the next); then compound 2.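

In this assay, hydroxymethyl on the triple-bonded carbon cannot be told apart from the longer chains, whether butyl (a 1.5-fold lower number from compound 3 to compound 4 (0.18 log units; within the scatter)) or 4-fluorobutyl (a 1.0-fold lower number from compound 1 to compound 4 (0.01 log units; within the scatter)). A hydroxy group on this short chain therefore does not by itself go with a higher number. The step that lies beyond the scatter separates two hydroxy-bearing groups, hydroxymethyl and 1-hydroxy-1-methylethyl (a 3.1-fold lower number from compound 2 to compound 4 (0.49 log units; beyond the scatter)), so the higher number of compound 2 cannot be read as an effect of the hydroxy group alone.

On these data alone, how an amine, a carboxylic acid or a longer hydroxyalkyl chain would fare at this place remains open. No evidence shown explains these numbers.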